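Quinone for hydroquinone on a pyrazole: cytotoxicity notes

The source may hold more compounds than are shown below. What is called first, only, known or untested is meant among the compounds shown, and "the series" means these compounds.

Measured compounds:
compound 1 `Oc1ccc(O)c(-c2cc(-c3ccc(Cl)cc3)nn2-c2ccccc2)c1`: 60400 nM
compound 2 `CC(=O)NS(=O)(=O)c1ccc(-n2nc(-c3ccccc3)cc2-c2cc(O)ccc2O)cc1`: 100000 nM
compound 3 `O=C1C=CC(=O)C(c2cc(-c3ccc(Cl)cc3)nn2-c2ccccc2)=C1`: 81700 nM

In a functional assay on cells (Cancer cell lines, Homo sapiens) for cytotoxicity, read by sulforhodamine B assay, with a stated time of 48 h (a lower number here means a stronger inhibitor of growth, a higher number a weaker inhibitor of growth), compound 1 gives 60400 nM, compound 3 gives 81700 nM and compound 2 gives 100000 nM. All three lie within the scatter of one another.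

The change from compound 1 to compound 3 is a group of 8 heavy atoms (6 carbon, 2 oxygen; one six-membered non-aromatic ring of carbon only) in place of a group of 8 heavy atoms (6 carbon, 2 oxygen; one six-membered aromatic ring of carbon only), on an aromatic carbon, and the step it made was a 1.4-fold higher number from compound 1 to compound 3 (0.13 log units; within the scatter).

Compound 4 `CC(=O)NS(=O)(=O)c1ccc(-n2nc(-c3ccccc3)cc2C2=CC(=O)C=CC2=O)cc1` is not yet measured. It differs from compound 2 by a group of 8 heavy atoms (6 carbon, 2 oxygen; one six-membered non-aromatic ring of carbon only) in place of a group of 8 heavy atoms (6 carbon, 2 oxygen; one six-membered aromatic ring of carbon only), on an aromatic carbon. This is the same kind of change as that from compound 1 to compound 3, though the surroundings differ: there the place lay next to the ring atom that bears a phenyl group and two ring bonds from the ring atom that bears a 4-chlorophenyl group, here it lies next to the ring atom that bears a large group and two ring bonds from the ring atom that bears a phenyl group. The difference between the cores of compound 1 and compound 2 is not broken down here.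

Within the data shown here, for compound 4 in this assay a step of about no change at the digits printed from compound 2 to compound 4 (within the scatter) is expected, resting on the single earlier step of a 1.4-fold higher number from compound 1 to compound 3 (0.13 log units; within the scatter), which stayed within the scatter. Compound 4 is therefore estimated at 100000 nM, with a range of 55000 nM to 200000 nM.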

Compound 4, concentration for total growth inhibition: 100000 nM
The estimate for compound 4 equals the measured number at the digits printed, and the stated range covers the measured number.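

In this assay, putting the six-membered non-aromatic ring of carbon only in place of 2,5-dihydroxyphenyl gives no change at the digits printed from compound 2 to compound 4 (within the scatter). Set beside the earlier step, the same change on the two cores shows no difference that can be told from scatter: the same change on two cores in this assay, a 1.4-fold higher number (0.13 log units; within the scatter) from compound 1 to compound 3 and no change at the digits printed (within the scatter) from compound 2 to compound 4, 1.4-fold (0.13 log units) apart, within the scatter of two such steps. This shows that the change stayed within the scatter on both cores, but it does not show that it would do so on any other core, and two such steps establish no general rule for the series.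

Going by these compounds, whether any change can move the number beyond the scatter remains open. On these data alone, the step for an amine or a carboxylic acid in place of the 2,5-dihydroxyphenyl group also remains unknown.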